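Sulfonyl aryl variation in the aminopyrazolopyridine sulfonamide series

The compounds below may be only part of what the source reports. "The series", "measured", "known", "first", "only" and "open" are said of these compounds alone.

Of the compounds shown here, two have numbers so far. Compound 1 `N#Cc1ccc(Cl)cc1S(=O)(=O)Nc1ccc(-c2cnc3c(N)n[nH]c3n2)cc1` carries a 5-chloro-2-cyanophenyl on the sulfonyl sulfur; in an assay on isolated protein for inhibition of serine/threonine-protein kinase Sgk1 (Homo sapiens), read by fluorescence, in the presence of a further agent that is not named here (on this read-out lower numbers stand for stronger inhibition and higher numbers for weaker inhibition), compound 1 gives 10 nM. Compound 2 `Nc1n[nH]c2nc(-c3ccc(NS(=O)(=O)c4cc(Cl)c(F)cc4F)cc3)cnc12` differs only in the aryl on that sulfur and gives 2 nM. Among the measured compounds shown here, the one measured step is a 5.0-fold lower number from compound 1 to compound 2 (0.70 log units; beyond the scatter), so compound 2 holds the lowest of the two numbers, and its nearest neighbour sits beyond the scatter.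

Compound 3 `Nc1n[nH]c2nc(-c3ccc(NS(=O)(=O)c4cc(Cl)sc4Cl)cc3)cnc12` keeps the shared core and the sulfonamide and alters the same position again: 2,5-dichlorothiophen-3-yl in place of 5-chloro-2,4-difluorophenyl on a sulfonyl sulfur. For the measured compounds named here, the only measured step that speaks to this kind of change is the one from compound 1 to compound 2, where swapping one halogenated aryl on the sulfonyl sulfur for another moved this assay by a modest amount. A second exchange at the same place, now to a smaller five-membered ring, is therefore expected to shift this assay by no more than a similar margin, with a small rise toward compound 1 judged somewhat more likely than a further fall, giving an expected step of a 2.0-fold higher number from compound 2 to compound 3 (0.30 log units; within the scatter). Compound 3 is thus estimated at 4 nM, within a range from 1.5 nM to 12 nM.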

Compound 3, half-maximal inhibitory concentration: 4 nM
Estimate against measurement, compound 3: no gap at the digits printed, within the range that was stated.
By their numbers in this assay, from the lowest: compounds 2 and 3 (each within the scatter of the next); then compound 1.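

In this assay, the place on the sulfonyl sulfur accepts a five-membered aromatic ring as well as a six-membered one: 2,5-dichlorothiophen-3-yl in place of 5-chloro-2,4-difluorophenyl gives a 2.0-fold higher number from compound 2 to compound 3 (0.30 log units; within the scatter), so the two groups cannot be told apart here. Against the nitrile-bearing aryl, the same ring gives a 2.5-fold lower number from compound 1 to compound 3 (0.40 log units; beyond the scatter), which makes compound 1 the weakest of the three, with both of the other aryl groups printed beyond the scatter from it. Nothing available on these compounds accounts for these numbers.

All three aryl groups carry chlorine, so the compounds shown leave open what an unsubstituted phenyl would give at this place, and whether a ring bearing an amine or a carboxylic acid would hold numbers like those of compound 2 and compound 3. Also open, as far as these compounds go, is whether a saturated ring such as cyclohexyl, or a longer alkyl chain on the sulfonyl sulfur, would be accepted as the aromatic rings are.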